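The compounds below may be only part of what the source reports. "The series", "measured", "known", "first", "only" and "open" are said of these compounds alone.

Measured compounds:
compound 1, `Cc1cccc(N2CCN(CCCCNc3nc(NCc4ccco4)c4cc(F)ccc4n3)CC2)c1C`, in a functional assay on MCF7 cells (Homo sapiens) for cytotoxicity, read by MTT assay, with a stated time of 2 days, tested at 10 uM; on this read-out lower numbers stand for less inhibition and higher numbers for more inhibition at the one concentration tested (going by the name of the read-out): 97.7%
compound 2, `Clc1cccc(N2CCN(CCCCNc3nc(NCc4ccco4)c4ccccc4n3)CC2)c1Cl`, in this assay: 95.8%

Both compounds carry the same core, an amine in a ring joined through a four-carbon chain to the rest of the molecule, and both nearly abolish the growth signal of the cells at the single concentration tested. Compound 2 stands within the scatter of compound 1: the gap between the two numbers is smaller than what repeated measurements of this kind usually show, so neither compound can be told apart from the other on these two values alone.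

The next compound, compound 3, is `Cc1cccc(N2CCN(CCCCNc3nc(NCc4ccco4)c4ccccc4n3)CC2)c1C`. Set against compound 2, it differs in one place: 2,3-dimethylphenyl in place of 2,3-dichlorophenyl on an amine nitrogen in a ring. The same 2,3-dimethylphenyl group is already present in compound 1, whose number in this assay lies within the scatter of that of compound 2. Given that, no change beyond the scatter is expected for the step of a number 0.7 percentage points higher from compound 2 to compound 3 (within the scatter). Compound 3 is therefore estimated to give about 96.5%, with a likely range from 88% to 99.5%.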

Compound 3, a percentage reported as inhibition, at one concentration (the size of the read-out at that concentration, not a potency): 95.8%
Estimate against measurement, compound 3: 0.7 percentage points above, within the range that was stated.
By their numbers in this assay, from the lowest: compounds 2, 3 and 1 (each within the scatter of the next).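

Compounds 1 and 2 differ in two places, so they could not show what either change does alone; compound 3 separates the two. In this assay, 2,3-dimethylphenyl in place of 2,3-dichlorophenyl on the amine nitrogen in the ring gives no change at the digits printed from compound 2 to compound 3 (within the scatter), so this pair of groups cannot be told apart at this position, with the rest of the molecule held the same. Hydrogen in place of fluoro on an aromatic carbon gives a number 1.9 percentage points lower from compound 1 to compound 3 (within the scatter), so that swap also stays within the usual scatter, and no measurement here offers a reason for either result.

All three compounds give high numbers at a single concentration, so these values leave open whether the groups would separate at lower concentrations, where the inhibition would be less complete. Also open, going by these compounds, is whether a quite different group on that ring nitrogen, such as a methoxy-substituted phenyl or a carboxylic acid on the phenyl ring, would give a number beyond the scatter.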